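Hexyl Carbamate: Stretching the Chain Beyond Allyl

The source may report more compounds than this note shows. Statements on the series, on what has been measured and on what is new or still open speak of the compounds shown alone.

The three measured compounds share one core and differ only in the group on the saturated chain carbon bound to an oxygen next to a carbonyl group. Compound 1 `CCCCOC(=O)Nc1ccc([Se]C#N)cc1` gives 12400 nM in a functional assay on PC-3 cells (Homo sapiens) for cytotoxicity, read by MTT assay, with a stated time of 72 h; a lower number here means a stronger inhibitor of growth, a higher number a weaker inhibitor of growth. Compound 2 `CC(C)COC(=O)Nc1ccc([Se]C#N)cc1` gives 21600 nM, and compound 3 `C=CCOC(=O)Nc1ccc([Se]C#N)cc1` gives 17600 nM. Compound 3 stands with the second highest number of the three; the steps of a 1.4-fold higher number from compound 1 to compound 3 (0.15 log units; within the scatter) and a 1.2-fold lower number from compound 2 to compound 3 (0.09 log units; within the scatter) are both within the scatter, as is a 1.7-fold higher number from compound 1 to compound 2 (0.24 log units; within the scatter). Compound 4 `CCCCCCOC(=O)Nc1ccc([Se]C#N)cc1` differs from compound 3 by pentyl in place of vinyl on a saturated chain carbon bound to an oxygen next to a carbonyl group. The measured steps that bear on this change are the three swaps at the same place, and none of them rose above the scatter, so the chain at this place has so far made no difference that can be trusted. A step beyond the scatter is therefore not expected in this assay in either direction; the expected step is a 1.4-fold lower number from compound 3 to compound 4 (0.13 log units; within the scatter). Compound 4 is estimated at 13000 nM, with a range from 5000 nM to 32000 nM.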

Compound 4, concentration for 50% growth inhibition: 17300 nM
Compound 4: the middle estimate sits 1.3-fold (0.12 log units) below what was measured; low and high end bracket the measured number.
By their numbers in this assay, from the lowest: compounds 1, 4, 3 and 2 (each within the scatter of the next).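

In this assay the swap of vinyl for pentyl, which read one bond further out is allyl to hexyl, gives a 1.0-fold lower number from compound 3 to compound 4 (0.01 log units; within the scatter) and so shows that this longer chain on a saturated chain carbon bound to an oxygen next to a carbonyl group leaves the number unmoved beyond the scatter. The comparisons with the other two groups agree, with a 1.2-fold lower number from compound 2 to compound 4 (0.10 log units; within the scatter) and a 1.4-fold higher number from compound 1 to compound 4 (0.14 log units; within the scatter) for ethyl in place of hydrogen at the end of the chain, so straight, branched and double-bonded groups of these sizes all lie within the scatter of one another. Nothing measured here offers an explanation for this flat result.

From the compounds shown here alone, whether a chain longer than hexyl would give a step beyond the scatter remains open. So does the effect of a benzyl group, or of a chain ending in an amine or a carboxylic acid, at this place.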